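Swapping the benzylselanyl group for methylsulfanyl on two cores

The source may report more compounds than this note shows. Statements on the series, on what has been measured and on what is new or still open speak of the compounds shown alone.

Of the compounds shown here, three have been measured in a functional assay on PC-3 cells (Homo sapiens) for cytotoxicity, read by MTT assay, with a stated time of 72 h; a higher number here means a weaker inhibitor of growth, a lower number a stronger inhibitor of growth. Compound 2 `O=C(/N=C(/NC(=O)c1ccno1)[Se]Cc1ccccc1)c1ccno1` gives 53100 nM, and compound 1 `CS/C(=N\C(=O)c1ccno1)NC(=O)c1ccno1` gives 99200 nM. The change between them, (a group of 2 heavy atoms (1 carbon, 1 sulfur; no ring) in place of a group of 8 heavy atoms (7 carbon, 1 selenium; one six-membered aromatic ring of carbon only), on a carbon with a double bond to nitrogen), produced a 1.9-fold higher number from compound 2 to compound 1 (0.27 log units; within the scatter). Compound 3 `O=C(/N=C(/NC(=O)c1cc(-c2ccccc2)nc2ccccc12)[Se]Cc1ccccc1)c1cc(-c2ccccc2)nc2ccccc12` carries a different core and gives 39300 nM in this assay; the difference between its core and the core of compound 2 is not broken down here, and its values next to those of compound 2 lie within the scatter of each other.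

Compound 4 `CS/C(=N\C(=O)c1cc(-c2ccccc2)nc2ccccc12)NC(=O)c1cc(-c2ccccc2)nc2ccccc12` has not yet been measured. It differs from compound 3 by a group of 2 heavy atoms (1 carbon, 1 sulfur; no ring) in place of a group of 8 heavy atoms (7 carbon, 1 selenium; one six-membered aromatic ring of carbon only), on a carbon with a double bond to nitrogen, the same change already seen from compound 2 to compound 1, on the same kind of carbon. For the measured compounds named here, the only guide is that earlier step, which stayed within the scatter. On that basis the step from compound 3 to compound 4 is expected to be about a 1.9-fold higher number from compound 3 to compound 4 (0.28 log units; within the scatter), because compound 2 to compound 1 gave a 1.9-fold higher number from compound 2 to compound 1 (0.27 log units; within the scatter). Compound 4 is therefore expected to give roughly 75000 nM, plausibly between 35000 nM and 160000 nM.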

Compound 4, concentration for 50% growth inhibition: 7480 nM
Beside the measured number, compound 4's estimate is 10-fold (1.00 log units) above it, and the stated range ends above it.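

Placing methylsulfanyl on the carbon with a double bond to nitrogen gives, in this assay, a 5.3-fold lower number from compound 3 to compound 4 (0.72 log units; beyond the scatter) on this core, which does not repeat what the same swap did on the other core, and the gap between the two results is larger than scatter alone would allow: the same change on two cores in this assay, a 1.9-fold higher number (0.27 log units; within the scatter) from compound 2 to compound 1 and a 5.3-fold lower number (0.72 log units; beyond the scatter) from compound 3 to compound 4, 9.8-fold (0.99 log units) apart, beyond the scatter of two such steps.

So in this pair of cores, the outcome of the swap depends on the core that carries it, and a step measured on one core does not predict the step on the other. For the compounds shown here, with only two cores, this does not show why they differ, nor that methylsulfanyl would lower the number on any further core.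

The swap exchanges selenium for sulfur and removes the aromatic ring in a single move, so these four compounds cannot tell which of the two matters on either core. A benzylsulfanyl group or a methylselanyl group on both cores would pull those two parts apart.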